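This account rests on a few compounds, and the source may have more. Where it says the series, first, only, none or still open, it means among the compounds named here.

Going by the values given here, in a toxicity assay on cells (Fibroblast, Homo sapiens) for cytotoxicity (a higher number here means a weaker inhibitor, a lower number a stronger inhibitor), compound 1 `CC(/C=C/C1=CCCCC1(C)C)=C\C=C\C(C)=C\COC(=O)c1c(O)cccc1O` gives 14000 nM and compound 2 `COc1cccc(C(=O)OC/C=C(C)/C=C/C=C(C)/C=C/C2=CCCCC2(C)C)c1O` gives 27000 nM, so compound 2 stands within the scatter of the only other measured value. Compound 3 `COc1cccc(O)c1C(=O)OC/C=C(C)/C=C/C=C(C)/C=C/C1=CCCCC1(C)C` differs from compound 2 by 2-hydroxy-6-methoxyphenyl in place of 2-hydroxy-3-methoxyphenyl on a carbonyl carbon, with 2-hydroxy-6-methoxyphenyl in place of 2-hydroxy-3-methoxyphenyl on a carbonyl carbon. Among the compounds with values here, the one measured step bearing on this change is a 1.9-fold higher number from compound 1 to compound 2 (0.29 log units; within the scatter), which swaps the group at the same place. No step beyond the scatter is therefore expected in this assay. The expected step is a 1.4-fold lower number from compound 2 to compound 3 (0.13 log units; within the scatter). Compound 3 is estimated at 20000 nM, with an expected range from 9000 nM to 45000 nM.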

Compound 3, half-maximal inhibitory concentration: 230000 nM
Compound 3: middle estimate off by 12-fold (1.06 log units), on the low side; measured number above the stated range.
By their numbers in this assay, from the lowest: compounds 1 and 2 (each within the scatter of the next); then compound 3.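

In this assay, the same atoms rearranged at this place are enough to shift the number: 2-hydroxy-6-methoxyphenyl in place of 2-hydroxy-3-methoxyphenyl gives an 8.5-fold higher number from compound 2 to compound 3 (0.93 log units; beyond the scatter), whereas the earlier change here stayed within the scatter. Methyl in place of hydrogen on an oxygen on the aromatic ring gives a 16-fold higher number from compound 1 to compound 3 (1.22 log units; beyond the scatter), so the outcome at this place depends on where the methoxy group stands on the ring. Nothing available explains this difference. The compounds shown leave open whether the rise is specific to methoxy, or whether an ethoxy group or a fluorine at the same ring position would produce it too.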